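Series notes: one methoxy removed from the aryl ketone

The source may hold more compounds than are shown below. What is called first, only, known or untested is meant among the compounds shown, and "the series" means these compounds.

Among the compounds with values here, compound 2 `COc1ccc(C(=O)/C=C/c2cc(-c3cc(OC)c(OC)c(OC)c3)n[nH]2)cc1OC` gives -64% in a functional assay on NCI-H460 cells (Homo sapiens) for cytotoxicity, read by sulforhodamine B assay, with a stated time of 48 h, tested at 10 uM (on this read-out lower numbers stand for a stronger effect and higher numbers for a weaker effect at the one concentration tested), the lowest of the two numbers so far. Compound 1 `COc1cc(-c2cc(/C=C/C(=O)c3ccc(N)cc3)[nH]n2)cc(OC)c1OC` gives -32% in this assay, and the step of a number 32 percentage points lower from compound 1 to compound 2 (beyond the scatter) came with 3,4-dimethoxyphenyl in place of 4-aminophenyl on a carbonyl carbon. Compound 3 `COc1ccc(C(=O)/C=C/c2cc(-c3cc(OC)c(OC)c(OC)c3)n[nH]2)cc1` differs from compound 2 by hydrogen in place of methoxy on an aromatic carbon, on an aromatic carbon of a six-membered aromatic ring of carbon only, ortho to a methoxy group and meta to a large group, so that 3,4-dimethoxyphenyl becomes 4-methoxyphenyl. Within the data shown here, no measured step shows a methoxy being removed; the only step available, a number 32 percentage points lower from compound 1 to compound 2 (beyond the scatter), concerns a different exchange on that ring and bears on this one only loosely. The step of a number 12 percentage points higher from compound 2 to compound 3 (beyond the scatter) is therefore expected to be modest, if anything toward a higher number. Compound 3 is expected to give -52% in this assay, within -80% to -22%.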

Compound 3, a percentage reported as activity, at one concentration (the size of the read-out at that concentration, not a potency): -63%
For compound 3 the middle estimate is 11 percentage points above the measured one; the range from low to high includes it.
By their numbers in this assay, from the lowest: compounds 2 and 3 (each within the scatter of the next); then compound 1.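

In this assay the methoxy lost from 3,4-dimethoxyphenyl proves dispensable at this position: the change gives a number a number 1 percentage points higher from compound 2 to compound 3 (within the scatter) and leaves 4-methoxyphenyl level with the dimethoxy ring. Read with methoxy in place of amino on an aromatic carbon, the step to a number a number 31 percentage points lower from compound 1 to compound 3 (beyond the scatter) shows that a single methoxy is enough to carry the large shift first seen with 3,4-dimethoxyphenyl in place of 4-aminophenyl. Nothing available explains either result.

Still open, on these data alone, is what a hydroxy group, a chlorine atom or plain hydrogen would give in place of the methoxy that remains on 4-methoxyphenyl. Also open, as far as these compounds go, is whether compound 2 and compound 3 stay level at concentrations other than the one tested.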